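The source may report more compounds than this note shows. Statements on the series, on what has been measured and on what is new or still open speak of the compounds shown alone.

Of the compounds shown here, three that share a core have been measured in an assay on HEK293 cells for negative allosteric modulation of metabotropic glutamate receptor 5 (Homo sapiens), read by FLIPR, with a stated time of 1 h; a lower number here means a stronger inhibitor, a higher number a weaker inhibitor. Compound 1, with the structure `COc1ccccc1C#Cc1nc2c(s1)C(=O)NCC2`, gives only a limit of the assay, > 10000 nM, and no number. Compound 2, with the structure `CCN1CCc2nc(C#Cc3ccccc3)sc2C1`, gives 1200 nM. Compound 3, with the structure `Fc1cccc(C#Cc2nc3c(s2)CN(C2CCOC2)CC3)c1`, gives 400 nM. Among the two numbers that were obtained, compound 2 has the higher one, so it is the weaker inhibitor of the two, and its gap to compound 3 lies beyond the scatter of repeated measurements; compound 1 gives no number at all, because of the limit of > 10000 nM in this assay, at which 1 of the 3 values shown sits.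

The next compound, compound 4, with the structure `COC1CC(C(=O)N2CCc3nc(C#Cc4ccccc4)sc3C2)C1`, differs from compound 2 in one place: (3-methoxycyclobutyl)carbonyl in place of ethyl on an amine nitrogen in a ring. Among the measured compounds shown here, no pair among the measured compounds shows this kind of change, so its effect can only be guessed. The expectation is that compound 4 comes out somewhat stronger than compound 2, with a step of a 2.0-fold lower number from compound 2 to compound 4 (0.30 log units; within the scatter) that is expected to reach a little beyond the scatter. For compound 4 the estimated value in this assay is 600 nM, with a range from 150 nM to 2500 nM.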

Compound 4, half-maximal inhibitory concentration: > 10000 nM
Compound 4: only a limit was reported; the forecaster's own chance of this, stated with the estimate: 10%; middle value at least 16-fold (1.22 log units) from the limit.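

Among the compounds shown here, on the amine nitrogen in a ring, this is the first comparison in which only the group on that nitrogen changes, and it shows that this position does not accept every substituent: in this assay, (3-methoxycyclobutyl)carbonyl in place of ethyl gives an at least 8.3-fold higher number from compound 2 to compound 4 (0.92 log units; beyond the scatter). As far as these compounds go, compound 4 gives only a limit of the assay, > 10000 nM, and no number, so this step is a minimum and its true size stays unknown: the limit of > 10000 nM in this assay, at which 2 of the 4 values shown sit. The change also does several things at once, placing a carbonyl on the nitrogen and adding both a four-membered ring of carbon and a methoxy group, so this single step cannot show which part accounts for the loss.

An acetyl group on the same nitrogen would test the carbonyl with little else added, while a cyclobutyl group joined directly to the nitrogen would test the ring without the carbonyl, and neither case is covered by the compounds shown. Also open, from the compounds shown here alone, is whether a longer chain such as propyl, or a chain ending in an amine, would match or improve on the ethyl group of compound 2.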